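Swapping a pyrazole tail for a methoxyphenyl tail

This account rests on a few compounds, and the source may have more. Where it says the series, first, only, none or still open, it means among the compounds named here.

Going by the values given here, compound 2 `Cc1nn(-c2ncnc3nc[nH]c23)c2c1C(OCCn1cccn1)CC(=O)N2` gives the higher of the two numbers so far in a functional assay on HEK293 cells for agonist activity at G-protein coupled receptor 39 (Homo sapiens), read by scintillation proximity assay and inositol phosphate accumulation, with a stated time of 75 min (a higher number here means that more compound is needed for the effect, a lower number that less compound is needed), at 2270 nM. Among the compounds with values here, compound 1 `CCCCCCCCOC1CC(=O)Nc2c1c(C)nn2-c1ncnc2nc[nH]c12`, its only comparator, gives 388 nM; the step of a 5.9-fold higher number from compound 1 to compound 2 (0.77 log units; beyond the scatter) is the one measured change at this position. Compound 3 `COc1ccc(CCOC2CC(=O)Nc3c2c(C)nn3-c2ncnc3nc[nH]c23)cc1` differs from compound 2 by 4-methoxyphenyl in place of 1H-pyrazol-1-yl on a saturated chain carbon, two bonds along the chain from an oxygen on a saturated carbon. Within the data shown here, only that earlier step bears on this change, and it shows that the group at this spot can move the number well beyond the scatter. Compound 3 is expected to come part of the way back, a step of a 3.2-fold lower number from compound 2 to compound 3 (0.51 log units; beyond the scatter), giving an estimate of 700 nM with a range from 200 nM to 2500 nM.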

Compound 3, half-maximal effective concentration: 70 nM
For compound 3 the middle estimate is 10-fold (1.00 log units) above the measured one; the measured number lies below the stated range.
By their numbers in this assay, from the lowest: compound 3; then compound 1; then compound 2.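

In this assay, the change shows a 32-fold lower number from compound 2 to compound 3 (1.51 log units; beyond the scatter) and so a wider span at this position than the earlier step revealed. Replacing hexyl gives a 5.5-fold lower number from compound 1 to compound 3 (0.74 log units; beyond the scatter) as well, and since 1H-pyrazol-1-yl and 4-methoxyphenyl are both aromatic rings yet mark the two ends of the series, having an aromatic ring here does not by itself set the number. Nothing available explains the gap between these groups. Still open, on these data alone, is what the methoxy on the ring contributes, and how an unsubstituted phenyl or an amine would read at this chain carbon.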